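The source may report more compounds than this note shows. Statements on the series, on what has been measured and on what is new or still open speak of the compounds shown alone.

Compound 1 `CC[C@@H](Nc1c(C#N)c(-c2ccc(-c3cccc(C)c3)cc2)nc2cnccc12)C(N)=O` belongs to a set of three compounds sharing one core, each read in a physicochemical assay for lipophilicity, read by HPLC, at pH 7.5; on this read-out higher numbers stand for higher lipophilicity and lower numbers for lower lipophilicity. In this assay compound 1 gives 3. Compound 2 `CCOc1ccccc1-c1ccc(-c2nc3cnccc3c(C[C@H](C)C(N)=O)c2C#N)cc1` gives 3, so compound 1 stands level with it at the digits shown, and together these two are the lowest of the three numbers. Within the data shown here, compound 3 `CCOc1ccccc1-c1ccc(-c2nc3cnccc3c(N[C@H](CC(C)C)C(N)=O)c2C#N)cc1` gives 3.4, the one value standing apart. Among the measured compounds shown here, the single step with both ends measured, a number 0.40 log units higher from compound 2 to compound 3 (beyond the scatter), came with (1-carbamoyl-3-methylbutyl)amino in place of 2-carbamoylpropyl on an aromatic carbon.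

For the measured compounds named here, compound 4 `CC[C@@H](Nc1c(C#N)c(-c2ccc(-c3ccccc3C(C)C)cc2)nc2cnccc12)C(N)=O` has not yet been read in this assay. It differs from compound 1 in one place: 2-isopropylphenyl in place of 3-methylphenyl on an aromatic carbon. Going by the values given here, no measured step changes this part of the core, so the step from compound 2 to compound 3 bears on it only loosely, as the one case where a change of a side group moved the read-out beyond the scatter. By analogy, a modest rise is expected, with a number 0.50 log units higher from compound 1 to compound 4 (beyond the scatter). Compound 4 is therefore estimated at 3.5, within a range from 3.1 to 3.9.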

Compound 4, distribution coefficient: 3.5
Compound 4: middle estimate and measured number agree at the digits printed; the range from low to high includes it.
By their numbers in this assay, from the lowest: compounds 1 and 2 (each within the scatter of the next); then compounds 3 and 4 (each within the scatter of the next).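

In this assay, among these compounds, this is the only measured change at this place on the shared core, an aromatic carbon para to a large group, and the read-out responds to it: 2-isopropylphenyl in place of 3-methylphenyl gives a number 0.50 log units higher from compound 1 to compound 4 (beyond the scatter) for this pair. The entering group holds 9 heavy atoms against 7, all of them carbon, with no hydrogen-bond donors or acceptors and no net charge on either side, so a swap between two carbon-only aryl groups is enough to pass the scatter. Nothing at hand gives a reason for this rise.

Among the compounds shown here, the single step changes both the alkyl group and its place on the ring, so the two cannot be told apart without 2-methylphenyl or 3-isopropylphenyl at this carbon. As far as these compounds go, how the read-out would answer a phenyl ring bearing an amine or a carboxylic acid here also stays open.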